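Swapping a methyl for ethylsulfanyl on an acylguanidine scaffold

The source may report more compounds than this note shows. Statements on the series, on what has been measured and on what is new or still open speak of the compounds shown alone.

Of the compounds shown here, three sharing one core have been measured in a functional assay for inhibition of sodium/hydrogen exchanger (Oryctolagus cuniculus); a higher number here means a weaker inhibitor, a lower number a stronger inhibitor. Compound 1 `CCc1cc(Br)c(S(C)(=O)=O)cc1C(=O)N=C(N)N` gives 41 nM; compound 2 `Cc1cc(C)c(S(C)(=O)=O)cc1C(=O)N=C(N)N` gives 11 nM; compound 3 `Cc1cc(Br)c(C(=O)N=C(N)N)cc1S(C)(=O)=O` gives 70 nM. Compound 2 therefore stands at the lowest number of the three, with compound 1 the nearest and compound 3 the furthest, both separated from it by more than the usual scatter.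

Compound 4 `CCSc1cc(C)c(C(=O)N=C(N)N)cc1S(C)(=O)=O` has not yet been measured in this assay. It differs from compound 2 in one place: ethylsulfanyl in place of methyl on an aromatic carbon

Among the measured compounds shown here, only one single-point step among the measured compounds touches on replacing a methyl group on this ring: from compound 2 to compound 3 a 6.4-fold higher number from compound 2 to compound 3 (0.80 log units; beyond the scatter). For the measured compounds named here, that step concerns a bromo group rather than ethylsulfanyl, and no measured pair isolates the ethylsulfanyl change itself, so the guidance is indirect. Compound 1, which carries two changes at once relative to compound 2, also sits at a higher number than compound 2. On this basis a modest rise in the number, beyond the scatter, is expected from compound 2 to compound 4 a 2.3-fold higher number from compound 2 to compound 4 (0.36 log units; beyond the scatter). Compound 4 is estimated at 25 nM, within a range from 8 nM to 80 nM.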

Compound 4, half-maximal inhibitory concentration: 5.9 nM
For compound 4 the middle estimate is 4.2-fold (0.63 log units) above the measured one, outside the stated range (below it).
By their numbers in this assay, from the lowest: compounds 4 and 2 (each within the scatter of the next); then compounds 1 and 3 (each within the scatter of the next).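

In this assay the move to ethylsulfanyl reads as a 1.9-fold lower number from compound 2 to compound 4 (0.27 log units; within the scatter), so at this place, ortho to a methylsulfonyl group and para to a group of 6 heavy atoms, a group of 3 heavy atoms that includes sulfur takes the place of a methyl with no change that can be told from scatter. Among the compounds shown here, the earlier bromo step, a 6.4-fold higher number from compound 2 to compound 3 (0.80 log units; beyond the scatter), replaced the other methyl of compound 2, so this is the first direct reading at this place, and it shows that one carbon is not the limit of what the position can carry while the number stays level with compound 2. Nothing measured here explains why the number holds.

The compounds shown leave open whether the sulfur matters or the chain alone does, which an ethyl group or a methoxy group at the same place would help to separate. They also leave open how far this place reaches, since a longer chain such as butylsulfanyl, an amine or a carboxylic acid there could read quite differently.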